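This account rests on a few compounds, and the source may have more. Where it says the series, first, only, none or still open, it means among the compounds named here.

Three compounds share a core in which a carbonyl is joined through a double bond to a second aromatic ring. Compound 1 `COc1cc(O)c(CC=C(C)C)c(O)c1C(=O)/C=C/c1cccc([N+](=O)[O-])c1` carries a nitro group on that second ring; compound 2 `COc1cc(OC)c(C(=O)/C=C/c2ccc(C)cc2)c(OC)c1` carries a methyl; compound 3 `COc1cc(OC)c(C(=O)/C=C/c2cc(OC)c(OC)cc2OC)c(OC)c1` carries three methoxy groups. In a functional assay on A549 cells (Homo sapiens) for inhibition, read by MTT assay, with a stated time of 72 h (a higher number here means a weaker inhibitor, a lower number a stronger inhibitor), compound 1 gives 15000 nM, compound 2 gives 15000 nM, and compound 3 gives 45100 nM. Compound 2 thus sits level with compound 1 at the digits shown, the two together giving the lowest numbers of the set, while compound 3 gives a number beyond the scatter above them.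

Compound 4 `COc1cc(OC)c(C(=O)/C=C/c2ccc(N)cc2)c(OC)c1` has not yet been measured. It differs from compound 2 by one change (amino in place of methyl on an aromatic carbon). For the measured compounds named here, no measured pair in this set shows the same change, so its effect can only be guessed. Since compound 2 gives 15000 nM, compound 4 is expected to land close by, with a step of a 1.5-fold lower number from compound 2 to compound 4 (0.18 log units; within the scatter) that may not exceed the scatter. The estimate for compound 4 is 10000 nM, within a range from 3000 nM to 40000 nM.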

Compound 4, half-maximal inhibitory concentration: > 50000 nM
Compound 4 gave a limit, no number; the forecaster's own chance of this, stated with the estimate: 10%; at least 5.0-fold (0.69 log units) between middle value and limit.
By their numbers in this assay, from the lowest: compounds 1 and 2 (each within the scatter of the next); then compound 3. At a limit, above all of these: compound 4.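

The reading for compound 4 is a limit of the assay, not a number: the limit of > 50000 nM in this assay, at which 1 of the 4 values shown sits. For the compounds shown here, the earlier compounds differ from one another in more than one place, so this is the first single change that can be read in this assay: amino in place of methyl, on an aromatic carbon para to a large group, gives an at least 3.3-fold higher number from compound 2 to compound 4 (0.52 log units; beyond the scatter). This position is therefore not indifferent to what it carries, and even this small exchange weakens inhibition, by an amount that the limit leaves without an upper end.

One step cannot show whether the loss belongs to amino itself or to the removal of methyl. As far as these compounds go, a dimethylamino group, a carboxylic acid or a longer chain such as ethyl at this position would be needed to separate these, and whether the same change behaves alike elsewhere on the shared core remains open.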